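Notes on the step from compound 3 to compound 4

The source may report more compounds than this note shows. Statements on the series, on what has been measured and on what is new or still open speak of the compounds shown alone.

Measured so far in a functional assay on cells (Melanoma cell, Homo sapiens) for cytotoxicity, read by sulforhodamine B assay, with a stated time of 48 h; on this read-out lower numbers stand for stronger inhibition of growth and higher numbers for weaker inhibition of growth:
compound 1 `COc1ccc(C2CC(c3ccccc3)=NN2C2=NC(=O)/C(=C3\C(=O)Nc4ccc(Br)cc43)S2)cc1` gives 210 nM
compound 2 `COc1ccc(C2=NN(C3=NC(=O)/C(=C4\C(=O)Nc5ccc(Br)cc54)S3)C(c3ccc(OC)cc3)C2)cc1` gives 190 nM
compound 3 `COc1ccc(C2=NN(C3=NC(=O)/C(=C4\C(=O)Nc5ccc(Cl)cc54)S3)C(c3ccc(OC)cc3)C2)cc1` gives 190 nM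

Compound 3 stands level with compound 2 at the digits shown, and the two together hold the lowest of the three numbers, while compound 1 lies within the scatter of both. For the measured compounds named here, the series so far is flat.

Compound 4 `COc1ccc(C2=NN(C3=NC(=O)/C(=C4\C(=O)Nc5ccc(Cl)cc54)S3)C(c3ccc(Cl)cc3)C2)cc1` differs from compound 3 by chloro in place of methoxy on an aromatic carbon. Going by the values given here, two steps bear on this. The first, a 1.1-fold lower number from compound 1 to compound 2 (0.04 log units; within the scatter), touched the same ring that changes here and stayed within the scatter. The second, no change at the digits printed from compound 2 to compound 3 (within the scatter), was a halogen exchange on the other aromatic ring and also stayed within the scatter. Among the compounds with values here, nothing among the measured steps points to a move beyond the scatter, so none is expected for compound 4.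

Compound 4 is accordingly estimated at 220 nM, with a range of 100 nM to 480 nM, which means an expected 1.2-fold higher number from compound 3 to compound 4 (0.06 log units; within the scatter).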

Compound 4, concentration for 50% growth inhibition: 200 nM
Beside the measured number, compound 4's estimate is 1.1-fold (0.04 log units) above it, and the stated range covers the measured number.
By their numbers in this assay, from the lowest: compounds 2, 3, 4 and 1 (each within the scatter of the next).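

In this assay the change from 4-methoxyphenyl to 4-chlorophenyl gives a 1.1-fold higher number from compound 3 to compound 4 (0.02 log units; within the scatter) and so shows that this position, previously probed only with hydrogen and methoxy, also accepts a halogen. The step removes the hydrogen-bond acceptor of the methoxy and one heavy atom, yet the number stays within the scatter. Nothing at hand accounts for this flat response.

As far as these compounds go, whether an amine, a carboxylic acid or a longer alkoxy chain at this position would leave the number within the scatter remains open.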